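The source may hold more compounds than are shown below. What is called first, only, known or untested is meant among the compounds shown, and "the series" means these compounds.

Compound 2, with the structure `Cc1ccc(C)c(-n2nncc2CN2C(=O)C3(C(C#N)=C(N)Oc4c(N)cc5nc6ccccc6nc5c43)c3ccccc32)c1`, is measured only as a limit in an ADME assay on L02 cells (Homo sapiens) for antiproliferative activity, read by MTT assay, with a stated time of 48 h; a higher number here means a weaker inhibitor, a lower number a stronger inhibitor: compound 2 gives > 50000 nM, a limit of the measurement rather than a number. For the measured compounds named here, its one neighbour, compound 1 `COc1ccccc1-n1nncc1CN1C(=O)C2(C(C#N)=C(N)Oc3c(N)cc4nc5ccccc5nc4c32)c2ccccc21`, sits at the same limit; in this assay compound 1 gives > 50000 nM. Going by the values given here, the single step between them, a step that the two limits leave unreadable from compound 1 to compound 2, therefore cannot be read in size or direction, and the only evidence is the limit of > 50000 nM in this assay, at which 2 of the 2 values shown sit. Compound 3, with the structure `COc1cc(-n2nncc2CN2C(=O)C3(C(C#N)=C(N)Oc4c(N)cc5nc6ccccc6nc5c43)c3ccccc32)c(OC)cc1Cl`, is not yet measured. It differs from compound 2 as follows: 4-chloro-2,5-dimethoxyphenyl in place of 2,5-dimethylphenyl on an aromatic nitrogen. Among the compounds with values here, no measured step bears on this change, so no direction is expected beyond the scatter, and the most likely outcome is that compound 3 again only reaches the limit. Compound 3 is estimated at 60000 nM, within a range of 20000 nM to 200000 nM. The step this estimate means is expected to be a step that the limit leaves unreadable from compound 2 to compound 3.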

Compound 3, half-maximal inhibitory concentration: > 50000 nM
Compound 3: no number, only a limit; the forecaster's own chance of this, stated with the estimate: 80%; the middle value lies beyond the limit too.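

Compound 3, like compound 1 and compound 2, stays at a limit in this assay and gives no number, so the steps among these three compounds cannot be read. The compounds shown leave open whether changing the group on the aromatic nitrogen alters the result at all.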